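Carbamate and urea side chains on a shared core

This account rests on a few compounds, and the source may have more. Where it says the series, first, only, none or still open, it means among the compounds named here.

Measured compounds and values:
Compound 1, `CCN(CC)c1cc2[nH]c(C3CCCCC3)nc2cc1NC(=O)OCCOCCOC`, gives > 100 ug/mL in an ADME assay on Vero cells (Chlorocebus sabaeus) for cytotoxicity, read by resazurin assay, with a stated time of 3 days (on this read-out lower numbers stand for stronger inhibition and higher numbers for weaker inhibition), which is a limit of the assay.
Compound 2, `Cc1ccc(C(=O)Nc2cc3nc(C4CCCCC4)[nH]c3cc2N2CCCC2)cc1`, gives > 100 ug/mL in this assay, again a limit of the assay.
Compound 3, `CCCNC(=O)Nc1cc2nc(C3CCCCC3)[nH]c2cc1N(CC)CC`, gives > 100 ug/mL in this assay, also a limit of the assay.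

Compound 3 therefore stands at the same limit as the two other measured compounds; all three sit at the limit of > 100 ug/mL in this assay, at which 3 of the 3 values shown sit, so no ordering among them can be read.

Compound 4, `CCCCOC(=O)Nc1cc2nc(C3CCCCC3)[nH]c2cc1N(CC)CC`, is not yet measured. It differs from compound 3 by butoxy in place of propylamino on a carbonyl carbon.

For the measured compounds named here, the only measured step that touches the same carbonyl carbon is a step that the two limits leave unreadable from compound 1 to compound 3. Both ends of that step are limits, and its size cannot be read. Nothing measured here separates any two compounds in this assay, so no direction can be expected for the change from compound 3 to compound 4 beyond the scatter.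

Compound 4 is accordingly expected to give 150 ug/mL in this assay, with a range of 80 ug/mL to 400 ug/mL, most probably reported again as a limit. The step this estimate implies from compound 3 is a step that the limit leaves unreadable from compound 3 to compound 4, expected to be unreadable.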

Compound 4, half-maximal inhibitory concentration: > 100 ug/mL
Compound 4: a limit, no number; the forecaster's own chance of this, stated with the estimate: 85%; the middle value lies beyond the limit too.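

The steps reaching compound 4 from compound 3 and from compound 1 cannot be read in this assay, since both ends of each step are limits of the assay: the limit of > 100 ug/mL in this assay, at which 4 of the 4 values shown sit.

The compounds shown leave open whether butoxy and propylamino on the carbonyl carbon differ at all, and whether any compound of this series gives a number in this assay.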